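Decyl in place of 4-fluorophenyl: expected cytotoxicity of compound 4

The source may hold more compounds than are shown below. What is called first, only, known or untested is meant among the compounds shown, and "the series" means these compounds.

Compound 3 `CCCCCc1cc2ccccc2nc1-c1cn(-c2ccc(F)cc2)nn1` is measured in a functional assay on THP-1 cells (Homo sapiens) for cytotoxicity, read by MTT assay, with a stated time of 24 h; a lower number here means a stronger inhibitor, a higher number a weaker inhibitor. In this assay compound 3 gives > 100 ug/mL, which is a limit of the assay and not a number. Compound 1 `CCCCCCCCCCn1cc(-c2nc3ccccc3cc2CCCC)nn1` gives > 100 ug/mL in this assay, likewise a limit. Compound 2 `CCCCCCCCCCn1cc(-c2nc3ccccc3cc2CCC)nn1` gives > 100 ug/mL in this assay, again a limit. For the measured compounds named here, the only step between measured compounds, a step that the two limits leave unreadable from compound 1 to compound 2, is accordingly unreadable, and all three values sit at the limit of > 100 ug/mL in this assay, at which 3 of the 3 values shown sit. Compound 4 `CCCCCCCCCCn1cc(-c2nc3ccccc3cc2CCCCC)nn1` differs from compound 3 by decyl in place of 4-fluorophenyl on an aromatic nitrogen. Going by the values given here, no measured step covers this change directly. What bears on it is that compound 1 and compound 2 already carry decyl on the same ring nitrogen, with butyl or propyl beside the shared core, and both show only the limit. With every value at the limit no direction can be read, so no step beyond the scatter is expected. The expected step is a step that the limit leaves unreadable from compound 3 to compound 4, flat within the scatter. Compound 4 is expected at 150 ug/mL, in the range from 70 ug/mL to 400 ug/mL, most likely reported only as a limit.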

Compound 4, half-maximal inhibitory concentration: 88 ug/mL
Compound 4: middle estimate off by 1.7-fold (0.23 log units), on the high side, and the stated range covers the measured number.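

In this assay, for the compounds shown here, compound 4 gives 88 ug/mL, the only value that is a number and not a limit, so the change at this aromatic nitrogen gains a floor: an at least 1.1-fold lower number from compound 3 to compound 4 (0.05 log units; that floor lies within the scatter). With decyl on that nitrogen, the saturated chain on the shared core gives two further floors: an at least 1.1-fold lower number from compound 2 to compound 4 (0.05 log units; that floor lies within the scatter) and an at least 1.1-fold lower number from compound 1 to compound 4 (0.05 log units; that floor lies within the scatter). All three floors lie within the scatter, so neither change is established as lowering the number, and most of the series remains at the limit: the limit of > 100 ug/mL in this assay, at which 3 of the 4 values shown sit.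

Going by these compounds, whether the value of compound 4 marks a real increase in cytotoxicity or merely lies close to the limit stays open. On these data alone, how a longer chain on the shared core or an amine in place of decyl would read in this assay also stays open.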